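This account rests on a few compounds, and the source may have more. Where it says the series, first, only, none or still open, it means among the compounds named here.

In an assay for inhibition of histone deacetylase 8 (Homo sapiens), read by fluorescence, with a stated time of 15 min (a lower number here means a stronger inhibitor, a higher number a weaker inhibitor), compound 1 `Nc1ccccc1NC(=O)c1ccc(CSC2=N[C@@H](c3ccccc3)CN2)cc1` gives 14300 nM, and compound 2 `Nc1ccccc1NC(=O)c1ccc(CNC2=N[C@@H](c3ccccc3)CN2)cc1` gives 5500 nM. Compound 3 `Nc1ccccc1NC(=O)c1ccc(CSC2=N[C@@H](Cc3ccccc3)CO2)cc1` gives 88000 nM in this assay, the highest of the three numbers; compound 1 is nearest to it and compound 2 furthest, both beyond the scatter. Compound 4 `Nc1ccccc1NC(=O)c1ccc(CSC2=N[C@@H](c3cccnc3)CO2)cc1` has not been measured. It differs from compound 3 by pyridin-3-yl in place of benzyl on a saturated ring carbon. Going by the values given here, no measured pair differs in a single place, so the step has no direct precedent here. The step from compound 3 to compound 4 is expected to be a modest one toward a lower number, a 2.2-fold lower number from compound 3 to compound 4 (0.34 log units; beyond the scatter). Compound 4 is therefore estimated at 40000 nM, within a range from 10000 nM to 150000 nM.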

Compound 4, half-maximal inhibitory concentration in the histone deacetylase 8 assay: 112000 nM
The estimate for compound 4 lay 2.8-fold (0.45 log units) below the measured number; measured number inside the range.
By their numbers in the histone deacetylase 8 assay, from the lowest: compound 2; then compound 1; then compounds 3 and 4 (each within the scatter of the next).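

In the histone deacetylase 8 assay, pyridin-3-yl in place of benzyl on this saturated ring carbon does not separate the two compounds: a 1.3-fold higher number from compound 3 to compound 4 (0.10 log units; within the scatter). In a physicochemical assay for lipophilicity, read by HPLC (on this read-out lower numbers stand for lower lipophilicity and higher numbers for higher lipophilicity), compound 3 gives 5.41 and compound 4 gives 3.19. Going by these compounds alone, in the physicochemical assay, the same change has a large effect on measured lipophilicity: the measured distribution coefficient of compound 3, 5.41, and of compound 4, 3.19, a number 2.22 log units lower (beyond the scatter) The two read-outs therefore part at this position, which the earlier compounds could not show, since none of them formed a pair differing in a single place.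

On these data alone, it remains open whether an amine or a carboxylic acid on this ring carbon would move the number in the histone deacetylase 8 assay. Also open, as far as these compounds go, is whether the same change would behave alike on the core of compound 1.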